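A Phenyl Ring Replaces the Methylated Alkene Linker

This account rests on a few compounds, and the source may have more. Where it says the series, first, only, none or still open, it means among the compounds named here.

The three measured compounds in a functional assay on HT-29 cells (Homo sapiens) for inhibition, read by MTT assay, with a stated time of 120 h (on this read-out lower numbers stand for stronger inhibition and higher numbers for weaker inhibition), are these:
Compound 1 `O=C(/C=C/c1ccc(NC(=O)Nc2ccc(Cl)c(C(F)(F)F)c2)cc1)NC1CCC1` gives 4430 nM.
Compound 2 `CNC(=O)/C=C/c1ccc(NC(=O)Nc2ccc(Cl)c(C(F)(F)F)c2)cc1` gives 11700 nM.
Compound 3 `CNC(=O)/C(C)=C/c1ccc(NC(=O)Nc2ccc(Cl)c(C(F)(F)F)c2)cc1` reaches only > 50000 nM, which is a limit of this assay and not a number.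

Compound 3 thus stands at the weak end of the shown values: an at least 11-fold higher number from compound 1 to compound 3 (1.05 log units; beyond the scatter) and an at least 4.2-fold higher number from compound 2 to compound 3 (0.63 log units; beyond the scatter), and (the limit of > 50000 nM in this assay, at which 1 of the 3 values shown sits).

Compound 4 `CNC(=O)c1cccc(-c2ccc(NC(=O)Nc3ccc(Cl)c(C(F)(F)F)c3)cc2)c1` differs from compound 3 in one place: 3-(methylcarbamoyl)phenyl in place of 2-(methylcarbamoyl)prop-1-en-1-yl on an aromatic carbon. Within the data shown here, no measured step swaps the alkene for an aromatic ring, so this change is not directly covered. The two steps that reach compound 3 both add a methyl to the alkene, an at least 11-fold higher number from compound 1 to compound 3 (1.05 log units; beyond the scatter) and an at least 4.2-fold higher number from compound 2 to compound 3 (0.63 log units; beyond the scatter), and both cost heavily. Compound 4 removes that methyl together with the alkene, so the loss seen in compound 3 need not carry over, while the new ring itself has no precedent among the shown compounds.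

A downward step is therefore expected, an at least 2.5-fold lower number from compound 3 to compound 4 (0.39 log units; beyond the scatter), with compound 2 as the nearest point of reference. Compound 4 is estimated at 20000 nM, with a range from 4000 nM to 100000 nM.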

Compound 4, half-maximal inhibitory concentration: 29300 nM
Beside the measured number, compound 4's estimate is 1.5-fold (0.17 log units) below it; low and high end bracket the measured number.
By their numbers in this assay, from the lowest: compound 1; then compound 2; then compound 4. At a limit, above all of these: compound 3.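

In this assay, the 3-(methylcarbamoyl)phenyl group gives a measurable value where the methylated alkene did not, yet the step reads only as an at least 1.7-fold lower number from compound 3 to compound 4 (0.23 log units; that floor lies within the scatter), so no order between the two can be claimed. Compound 3 remains a limit of the assay and not a number: the limit of > 50000 nM in this assay, at which 1 of the 4 values shown sits. Set against the unmethylated alkene, the aromatic ring gives a 2.5-fold higher number from compound 2 to compound 4 (0.40 log units; beyond the scatter), and against the alkene with the cyclobutyl amide it gives a 6.6-fold higher number from compound 1 to compound 4 (0.82 log units; beyond the scatter), so at this position, on an aromatic carbon para to a large group, the ring does not recover the numbers of the plain ethenyl linkers.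

Going by these compounds, on the alkene, the change of amide group reads as a 2.6-fold higher number from compound 1 to compound 2 (0.42 log units; beyond the scatter), and whether a cyclobutyl amide on the phenyl ring would shift the number in the same way remains open. Also open, on these data alone, is how this assay would read with a carboxylic acid or a primary amine in place of the methylcarbamoyl group on the ring, or with a plain phenyl ring carrying neither.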